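A few compounds are considered here, and "the series" means these few. Any claim that something is new, unique, unknown or untested is made for them only; others in the source may bear on it.

Compound 1 `O=C(Nc1cccc(Oc2nccc(C(F)(F)F)c2Cl)c1)C1CCCN(C(=O)c2cc(C(F)(F)F)cc(C(F)(F)F)c2)C1` was tested in an ADME assay on PC-3 cells (Homo sapiens) for cytotoxicity, read by WST assay, tested at 100 uM (on this read-out lower numbers stand for less inhibition and higher numbers for more inhibition at the one concentration tested (going by the name of the read-out)), where compound 1 gives 0%. Two simpler relatives share its core. Compound 2 `COc1cccc(C(=O)N2CCCC(C(=O)Nc3ccc(Cl)cc3)C2)c1` gives 0% in this assay, and compound 3 `CC(=O)Nc1cccc(C(=O)N2CCCC(C(=O)Nc3ccc(Cl)cc3)C2)c1` gives 4%. Going by the values given here, the one measured step between neighbours, acetamido in place of methoxy on an aromatic carbon, moves the read-out by a number 4 percentage points higher from compound 2 to compound 3 (within the scatter), which stays inside the scatter. Compound 1 thus stands level with compound 2 at the digits shown, the two together at the bottom of the three numbers, while compound 3 sits only a few points higher, again inside the scatter. In short, none of the three compounds inhibits the cells to a measurable degree at the concentration tested.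

Compound 4 `O=C(Nc1cccc(N2CCCC2=O)c1)C1CCCN(C(=O)c2cc(C(F)(F)F)cc(C(F)(F)F)c2)C1` is the next step from compound 1. The change is 2-oxopyrrolidin-1-yl in place of (3-chloro-4-(trifluoromethyl)pyridin-2-yl)oxy on an aromatic carbon. Among the compounds with values here, no measured step touches this part of the molecule, so the only guide is the flat picture so far: every change seen, including the one from compound 2 to compound 3, left the read-out essentially unchanged near zero. The expected step is therefore a number 2 percentage points higher from compound 1 to compound 4 (within the scatter), nothing beyond the scatter. Compound 4 is estimated at 2%, in a range from 0% to 12%.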

Compound 4, a percentage reported as inhibition, at one concentration (the size of the read-out at that concentration, not a potency): 0%
Compound 4: the middle estimate sits 2 percentage points above what was measured; the measured number falls inside the stated range.
By their numbers in this assay, from the lowest: compounds 1, 2, 4 and 3 (each within the scatter of the next).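

Measured in this assay, the change at this position gives no change at the digits printed from compound 1 to compound 4 (within the scatter). Going by these compounds alone, this is the first measured change at this aromatic carbon, and it is a large one: a group of 12 heavy atoms with a six-membered aromatic ring, chlorine and fluorine gives way to a group of 6 heavy atoms with a five-membered non-aromatic ring and neither halogen, yet the read-out stays at the bottom of the measured numbers, so at this one concentration the number stays level across two very different groups at the place meta to a large group. No measurement available here accounts for this lack of change.

The compounds shown leave open whether any group on this aromatic carbon can lift the read-out beyond the usual scatter, for example a carboxylic acid or an amine, both absent from the compounds shown. Within the data shown here, they also leave open whether a longer chain carrying such a group would behave any differently, since every number so far lies close to zero and a read-out this low cannot separate the groups already compared.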